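The source may report more compounds than this note shows. Statements on the series, on what has been measured and on what is new or still open speak of the compounds shown alone.

In a functional assay on T47D cells (Homo sapiens) for inhibition (on this read-out lower numbers stand for stronger inhibition and higher numbers for weaker inhibition), compound 1 `Oc1ccccc1-c1cc(-c2cccc(F)c2)cc(-c2ccccc2O)n1` gives only a limit, > 50000 nM.
In this assay compound 2 `Oc1cccc(-c2cc(-c3cccc(F)c3)cc(-c3ccccc3O)n2)c1` likewise gives only a limit, > 50000 nM.
In this assay compound 3 `Oc1cccc(-c2cc(-c3ccc(OC(F)(F)F)cc3)cc(-c3ccccc3O)n2)c1` gives 7710 nM.

The change from compound 1 to compound 2 is 3-hydroxyphenyl in place of 2-hydroxyphenyl on an aromatic carbon. Its size stays hidden, a step that the two limits leave unreadable from compound 1 to compound 2, because both values sit at the limit of > 50000 nM in this assay, at which 2 of the 3 values shown sit. The difference between the cores of compound 1 and compound 3 is not broken down here. Compound 4 `Oc1cccc(-c2cc(-c3ccc(OC(F)(F)F)cc3)cc(-c3cccc(O)c3)n2)c1` remains to be measured and differs from compound 3 by 3-hydroxyphenyl in place of 2-hydroxyphenyl on an aromatic carbon, the same kind of change as the earlier one, though there the place was meta to a 2-hydroxyphenyl group and to a 3-fluorophenyl group, while here it is meta to a 3-hydroxyphenyl group and to a large group. The earlier step being unreadable, the expectation rests on compound 3 with 7710 nM alone. Compound 4 is therefore expected to give about 10000 nM, plausibly between 3000 nM and 40000 nM. That estimate corresponds to an expected step of a 1.3-fold higher number from compound 3 to compound 4 (0.11 log units; within the scatter).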

Compound 4, half-maximal inhibitory concentration: 9820 nM
Beside the measured number, compound 4's estimate is 1.0-fold (0.01 log units) above it; the measured number falls inside the stated range.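

In this assay, 3-hydroxyphenyl in place of 2-hydroxyphenyl gives a 1.3-fold higher number from compound 3 to compound 4 (0.11 log units; within the scatter), so on this core the change leaves the two values within the scatter of each other. The same change on the core of compound 1 cannot be read, because compound 1 and compound 2 both give only a limit: the limit of > 50000 nM in this assay, at which 2 of the 4 values shown sit. Going by these compounds alone, the transfer between cores therefore remains untested, and the single readable pair shows nothing about whether the result carries over to the core of compound 1.

The compounds shown leave open what an amine or a carboxylic acid would do in place of the hydroxy group of the 3-hydroxyphenyl group. They also leave open whether either group would shift the read-out on both cores.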